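Fluoro to methyl on the triazole-linked phenyl

The source may report more compounds than this note shows. Statements on the series, on what has been measured and on what is new or still open speak of the compounds shown alone.

In a functional assay on HT-29 cells (Homo sapiens) for cytotoxicity, read by MTT assay, with a stated time of 72 h (on this read-out lower numbers stand for stronger inhibition and higher numbers for weaker inhibition), compound 3 `COc1cc2c(Oc3ccc(NC(=O)c4cn(-c5ccccc5F)nn4)cc3F)ccnc2cc1OCCCN1CCC(C)CC1` gives 210 nM, the second highest of the three numbers available. Going by the values given here, its nearest neighbour is compound 2 `COc1cc2c(Oc3ccc(NC(=O)c4cn(-c5ccccc5Cl)nn4)cc3F)ccnc2cc1OCCCN1CCC(C)CC1` with 130 nM; the step of a 1.6-fold higher number from compound 2 to compound 3 (0.21 log units; within the scatter) is the only measured single-point change. Among the compounds with values here, compound 1 `COc1cc2c(Oc3ccc(NC(=O)c4cn(-c5ccccc5C)nn4)cc3F)ccnc2cc1OCCCN1CCCC1` gives 1200 nM; it shares the 2-methylphenyl of compound 4 but differs from compound 4 in another part of the molecule, so no direct step connects the two and their values can only be read side by side.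

Compound 4 `COc1cc2c(Oc3ccc(NC(=O)c4cn(-c5ccccc5C)nn4)cc3F)ccnc2cc1OCCCN1CCC(C)CC1` differs from compound 3 by methyl in place of fluoro on an aromatic carbon. Within the data shown here, no measured step covers a halogen-to-methyl exchange at this position; the one measured step at this carbon, from chloro to fluoro, stayed within the scatter, which suggests tolerance to small groups there but says nothing about methyl. The high number of compound 1 hints that the methyl may cost potency, yet that comparison is confounded.

For compound 4 the expected step is a 1.7-fold higher number from compound 3 to compound 4 (0.22 log units; within the scatter), a modest move to a higher number with wide uncertainty. The estimate for compound 4 in this assay is 350 nM, with a range from 120 nM to 1000 nM.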

Compound 4, half-maximal inhibitory concentration: 2380 nM
Estimate against measurement, compound 4: 6.8-fold (0.83 log units) below; the measured number lies above the stated range.
By their numbers in this assay, from the lowest: compounds 2 and 3 (each within the scatter of the next); then compounds 1 and 4 (each within the scatter of the next).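

In this assay this aromatic carbon proves far less permissive than the halogen pair suggested: a 1.6-fold higher number from compound 2 to compound 3 (0.21 log units; within the scatter) is small, whereas methyl gives an 11-fold higher number from compound 3 to compound 4 (1.05 log units; beyond the scatter) and an 18-fold higher number from compound 2 to compound 4 (1.26 log units; beyond the scatter), even though the exchange leaves the heavy-atom count unchanged. The amine exchange gives only a 2.0-fold higher number from compound 1 to compound 4 (0.30 log units; within the scatter), so 4-methylpiperidin-1-yl and pyrrolidin-1-yl do not separate the two 2-methylphenyl compounds, and both stay apart from the halogen compounds bearing 4-methylpiperidin-1-yl. Nothing available explains why methyl is so poorly tolerated here when the halogens are not.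

The compounds shown hold no methoxy, trifluoromethyl or ethyl group and no unsubstituted phenyl at this position, so it remains open whether the loss belongs to methyl alone or extends to other non-halogen groups. Going by these compounds alone, whether pyrrolidin-1-yl and 4-methylpiperidin-1-yl also read alike alongside 2-fluorophenyl or 2-chlorophenyl is equally open, since the amine exchange is seen only with 2-methylphenyl.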